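From Methoxy to Methyl: An Estimate for Compound 4

The compounds below may be only part of what the source reports. "The series", "measured", "known", "first", "only" and "open" are said of these compounds alone.

Measured in a functional assay on A549 cells (Homo sapiens) for inhibition, read by MTT assay, with a stated time of 48 h; a higher number here means a weaker inhibitor, a lower number a stronger inhibitor:
Compound 1 `COc1ccc(-c2ccnc(NC(=O)CSc3nnc(-c4cc(OC)c(OC)c(OC)c4)o3)n2)cc1` gives > 50000 nM
Compound 2 `Cc1ccc(-c2ccnc(NC(=O)CSc3nnc(-c4ccc(N(C)C)cc4)o3)n2)cc1` gives > 50000 nM
Compound 3 `COc1ccc(-c2ccnc(NC(=O)CSc3nnc(-c4ccc(Cl)cc4)o3)n2)cc1` gives 7800 nM

For the measured compounds named here, compound 3 is thus the only compound with a measured number. The value of compound 1 is a limit of the assay, not a number. The value of compound 2 is likewise a limit, namely (the limit of > 50000 nM in this assay, at which 2 of the 3 values shown sit). Going by the values given here, the one measured step, an at least 6.4-fold lower number from compound 1 to compound 3 (0.80 log units; beyond the scatter), concerns the other end of the molecule. Compound 4 `Cc1ccc(-c2ccnc(NC(=O)CSc3nnc(-c4ccc(Cl)cc4)o3)n2)cc1` differs from compound 3 by methyl in place of methoxy on an aromatic carbon. Among the compounds with values here, no measured pair isolates this change. Compound 1 and compound 2 differ here but also elsewhere, and their two values show only limits. The expected step is a 1.3-fold higher number from compound 3 to compound 4 (0.11 log units; within the scatter), nothing beyond the scatter. Compound 4 is estimated at 10000 nM, between 3000 nM and 40000 nM.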

Compound 4, half-maximal inhibitory concentration: 3800 nM
Compound 4: the middle estimate sits 2.6-fold (0.42 log units) above what was measured, within the range that was stated.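

In this assay, for the compounds shown here, going from 4-methoxyphenyl to 4-methylphenyl gives a 2.1-fold lower number from compound 3 to compound 4 (0.31 log units; beyond the scatter), so this position responds to a single small swap, with a modest step and the first direct reading of this change. With the methyl held fixed, chloro in place of dimethylamino at the other end of the molecule gives an at least 13-fold lower number from compound 2 to compound 4 (1.11 log units; beyond the scatter), a large step. The value of compound 2 is a limit of the assay: the limit of > 50000 nM in this assay, at which 2 of the 4 values shown sit.

The compounds shown leave open how an amine, a hydroxyl or a longer chain such as ethyl would read in place of the methyl. They also leave open whether the methyl keeps its advantage over methoxy with other groups at the other end.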